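The source may hold more compounds than are shown below. What is called first, only, known or untested is meant among the compounds shown, and "the series" means these compounds.

Compound 1 `COc1cc(C(=O)c2cn(-c3cccc(C)c3)cc2-c2ccccc2F)cc(OC)c1OC`: 190 nM
Compound 2 `COc1cc(C(=O)c2cn(-c3cccc(C)c3)cc2-c2ccccc2Cl)cc(OC)c1OC`: 420 nM
Compound 3 `COc1cc(C(=O)c2cn(-c3cccc(C)c3)cc2-c2cccc(N)c2)cc(OC)c1OC`: 130 nM

All three numbers come from a functional assay on MCF7 cells (Homo sapiens) for cytotoxicity, read by MTT assay, with a stated time of 96 h; a lower number here means a stronger inhibitor, a higher number a weaker inhibitor. Compound 2 gives the highest number of the three, 420 nM, which makes it the weakest inhibitor of this small set.

Compound 4 `COc1cc(C(=O)c2cn(-c3ccc(C)cc3)cc2-c2ccccc2Cl)cc(OC)c1OC` differs from compound 2 in one group: 4-methylphenyl in place of 3-methylphenyl on an aromatic nitrogen. This is 4-methylphenyl in place of 3-methylphenyl on an aromatic nitrogen, so the two compounds have the same atoms, joined differently.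

Every measured step changes a different group, the one on an aromatic carbon. Two of these steps are modest, a 2.2-fold higher number from compound 1 to compound 2 (0.34 log units; beyond the scatter) and a 3.2-fold lower number from compound 2 to compound 3 (0.51 log units; beyond the scatter), while a 1.5-fold lower number from compound 1 to compound 3 (0.16 log units; within the scatter) stays within the scatter. Among the measured compounds shown here, no measured pair changes the group on the nitrogen, so the data offer no direction for this swap and only a rough sense of how large single changes can be.

The expected change is a 1.1-fold lower number from compound 2 to compound 4 (0.02 log units; within the scatter), which means no step beyond the scatter in this assay. For compound 4 the estimated value is 400 nM, with an expected range of 150 nM to 1100 nM.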

Compound 4, half-maximal inhibitory concentration: 180 nM
Estimate against measurement, compound 4: 2.2-fold (0.35 log units) above, and the stated range covers the measured number.
By their numbers in this assay, from the lowest: compounds 3, 4 and 1 (each within the scatter of the next); then compound 2.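

Among the compounds shown here, until this result, every measured step changed a group on an aromatic carbon, so nothing showed how the group on the aromatic nitrogen affects the number. In this assay, 4-methylphenyl in place of 3-methylphenyl gives a 2.3-fold lower number from compound 2 to compound 4 (0.37 log units; beyond the scatter), a modest step but one beyond the scatter, so this position responds even when the atoms stay the same and only their arrangement differs. No measurement shown here explains this step.

On these data alone, this swap appears only in compounds carrying the 2-chlorophenyl group, so whether it has a similar effect with the 2-fluorophenyl group of compound 1 or the 3-aminophenyl group of compound 3 remains open. Also open, as far as these compounds go, is how the number would respond to other groups on the nitrogen, such as a plain phenyl or a 4-aminophenyl group.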